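The source may hold more compounds than are shown below. What is called first, only, known or untested is meant among the compounds shown, and "the series" means these compounds.

Of the compounds shown here, three built on one shared core have been measured in a functional assay on HUVEC cells (Homo sapiens), read by scintillation counting and thymidine incorporation, with a stated time of 24 h; on this read-out higher numbers stand for weaker inhibition and lower numbers for stronger inhibition. Compound 1 `CCC(C)n1ncn(-c2ccc(N3CCN(c4ccc(OC[C@@H]5CO[C@@](Cn6nc(C)nc6C)(c6ccc(Cl)cc6Cl)O5)cc4)CC3)cc2)c1=O` gives 221 nM in this assay, the highest of the three numbers, though its steps to the other two stay within the scatter. Compound 2 `CCC(C)n1ncn(-c2ccc(N3CCN(c4ccc(OC[C@@H]5CO[C@@](Cn6ccnc6C)(c6ccc(Cl)cc6Cl)O5)cc4)CC3)cc2)c1=O` gives 173 nM, and compound 3 `CCC(C)n1ncn(-c2ccc(N3CCN(c4ccc(OC[C@@H]5CO[C@@](Cn6ccnc6-c6ccccc6)(c6ccc(Cl)cc6Cl)O5)cc4)CC3)cc2)c1=O` gives 136 nM. The step of a 1.3-fold lower number from compound 1 to compound 2 (0.11 log units; within the scatter) and the step of a 1.6-fold lower number from compound 1 to compound 3 (0.21 log units; within the scatter) both lie within the scatter, as does a 1.3-fold lower number from compound 2 to compound 3 (0.10 log units; within the scatter), so the three numbers cannot be told apart.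

Compound 4 `CCC(C)n1ncn(-c2ccc(N3CCN(c4ccc(OC[C@@H]5CO[C@@](Cn6cnnn6)(c6ccc(Cl)cc6Cl)O5)cc4)CC3)cc2)c1=O` differs from compound 1 in one place: 1H-tetrazol-1-yl in place of 3,5-dimethyl-1H-1,2,4-triazol-1-yl on a saturated chain carbon bound to a saturated ring carbon. The two measured steps that bear on this, a 1.3-fold lower number from compound 1 to compound 2 (0.11 log units; within the scatter) and a 1.6-fold lower number from compound 1 to compound 3 (0.21 log units; within the scatter), each replaced the same group with another five-membered aromatic ring at the same place, and neither moved the number beyond the scatter. A step of the same kind is therefore expected here, none beyond the scatter. Compound 4 is expected to give about 200 nM in this assay, with a range from 80 nM to 500 nM, which means an estimated step of a 1.1-fold lower number from compound 1 to compound 4 (0.04 log units; within the scatter).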

Compound 4, half-maximal inhibitory concentration: 73 nM
Compound 4: middle estimate off by 2.7-fold (0.44 log units), on the high side, outside the stated range (below it).
By their numbers in this assay, from the lowest: compounds 4, 3, 2 and 1 (each within the scatter of the next, the first and the last beyond it).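

Among these compounds, at the saturated chain carbon bound to a saturated ring carbon, the ring can change the number in this assay after all: with 1H-tetrazol-1-yl, a 3.0-fold lower number from compound 1 to compound 4 (0.48 log units; beyond the scatter) and a 2.4-fold lower number from compound 2 to compound 4 (0.37 log units; beyond the scatter) are the only steps at this place that pass beyond the scatter, both of modest size, while a 1.9-fold lower number from compound 3 to compound 4 (0.27 log units; within the scatter) remains within it. Compared with the 3,5-dimethyl-1H-1,2,4-triazol-1-yl it replaces, 1H-tetrazol-1-yl has fewer heavy atoms, more nitrogen and no methyl groups, and these differences all arrive together in one change, so they cannot be separated here. Nothing available here explains the shift.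

Still open, from the compounds shown here alone, is which of those differences matters, and a 5-methyl-1H-tetrazol-1-yl or an unsubstituted 1H-1,2,4-triazol-1-yl at this place could help to separate them. Also open, going by these compounds, is whether a ring is needed there at all, which a simple amine or a carboxylic acid at the same place could test.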